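The source may report more compounds than this note shows. Statements on the series, on what has been measured and on what is new or still open speak of the compounds shown alone.

Among the measured compounds shown here, compound 1 `CCn1cc(COc2cc(O)c3c(c2)O[C@H](c2ccc(OC)c(O)c2)C/C3=N\O)nn1` is the lower of the two numbers measured so far in a functional assay on RAW264.7 cells (Mus musculus) for inhibition, read by Griess assay, with stated times of 2 h and 24 h; on this read-out higher numbers stand for weaker inhibition and lower numbers for stronger inhibition. In this assay compound 1 gives 3140 nM, while compound 2 `CCCn1cc(COc2cc(O)c3c(c2)O[C@H](c2ccc(OC)c(O)c2)CC3=O)nn1` gives 9670 nM, a gap beyond the scatter. Compound 3 `COc1ccc([C@@H]2C/C(=N\O)c3c(O)cc(OCc4cn(-c5ccccc5)nn4)cc3O2)cc1O` has not yet been measured and differs from compound 1 in one place: phenyl in place of ethyl on an aromatic nitrogen. For the measured compounds named here, no measured pair shows this change, so the step from compound 1 to compound 3 is expected to be small, perhaps a slight gain, as a 1.1-fold lower number from compound 1 to compound 3 (0.05 log units; within the scatter). Compound 3 is estimated at 2800 nM, with a range from 1100 nM to 7500 nM.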

Compound 3, half-maximal inhibitory concentration: 6130 nM
For compound 3 the middle estimate is 2.2-fold (0.34 log units) below the measured one; the measured number falls inside the stated range.
By their numbers in this assay, from the lowest: compounds 1, 3 and 2 (each within the scatter of the next, the first and the last beyond it).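

Phenyl in place of ethyl on this aromatic nitrogen gives a 2.0-fold higher number from compound 1 to compound 3 (0.29 log units; within the scatter) in this assay, the first one-place comparison at this position. With the rest of compound 1 unchanged, a six-membered aromatic ring of carbon only is thus tolerated here, and the read-out stays within the scatter. No measurement at hand offers a cause for this outcome.

Still open, on these data alone, is how an amine, a carboxylic acid or a longer chain on this nitrogen would read. Also open, as far as these compounds go, is whether phenyl behaves alike on the core of compound 2.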